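Methyl to Isopropyl on a Cytochrome P450 11B2 Inhibitor

The compounds below may be only part of what the source reports. "The series", "measured", "known", "first", "only" and "open" are said of these compounds alone.

Compound 1 `Fc1ccc2nc(-c3cnco3)n(C3CC3)c2c1`: > 10000 nM
Compound 2 `Fc1ccc2nc(-c3ccnnc3)n(C3CC3)c2c1`: 330 nM
Compound 3 `Cc1ncncc1-c1nc2cc(F)c(F)cc2n1C1CC1`: 17 nM

Of the compounds shown here, three have been measured in an assay on cells for inhibition of cytochrome P450 11B2, mitochondrial (Homo sapiens), read by HPLC, with a stated time of 90 min; on this read-out lower numbers stand for stronger inhibition and higher numbers for weaker inhibition. Compound 1 gives only a limit of the assay, > 10000 nM (the limit of > 10000 nM in this assay, at which 1 of the 3 values shown sits). Compound 2 gives 330 nM, and the step of an at least 30-fold lower number from compound 1 to compound 2 (1.48 log units; beyond the scatter) is large. Compound 3 gives 17 nM and stands lowest of the two numbers; its nearest neighbour is compound 2, and that gap is beyond the scatter.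

Compound 4 `CC(C)c1ncncc1-c1nc2cc(F)c(F)cc2n1C1CC1` is not yet measured. It differs from compound 3 by isopropyl in place of methyl on an aromatic carbon. Going by the values given here, the only measured step, an at least 30-fold lower number from compound 1 to compound 2 (1.48 log units; beyond the scatter), exchanges the whole ring and does not bear on this change, so no direction is supported beyond the scatter.

Compound 4 is therefore expected near 30 nM, between 8 nM and 150 nM. The expected step is a 1.8-fold higher number from compound 3 to compound 4 (0.25 log units; within the scatter).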

Compound 4, half-maximal inhibitory concentration: 5 nM
Compound 4: middle estimate off by 6.0-fold (0.78 log units), on the high side; the whole stated range lies above it.
By their numbers in this assay, from the lowest: compound 4; then compound 3; then compound 2. At a limit, above all of these: compound 1.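

In this assay, the step of a 3.4-fold lower number from compound 3 to compound 4 (0.53 log units; beyond the scatter) shows that this aromatic carbon, next to the ring nitrogen, accepts isopropyl in place of methyl, and that the larger group here goes with stronger inhibition rather than a loss. Going by these compounds alone, the only earlier step exchanged a whole ring and said nothing about this position. No measurement shown here bears on what lies behind this step.

From the compounds shown here alone, whether the trend continues with tert-butyl or a longer chain at this carbon remains open. So does the outcome with an amine or a methoxy group there.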